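Replacing the aryl arm of compound 1 with a pentyl chain

The source may hold more compounds than are shown below. What is called first, only, known or untested is meant among the compounds shown, and "the series" means these compounds.

Compound 1 `CN1CCC[C@@H]1Cn1nc(Cc2cccc(F)c2)c2ccccc2c1=O` is examined in an assay for binding affinity to Alpha-1A adrenergic receptor (Homo sapiens) (a lower number here means a stronger inhibitor, a higher number a weaker inhibitor), where compound 1 gives 50.1 nM. Two related compounds are measured in this assay: compound 2 `CN(C)CCn1nc(Cc2ccc(Cl)cc2)c2ccccc2c1=O` gives 158 nM, and compound 3 `CN1CCC(Cn2nc(Cc3ccc(Cl)cc3)c3ccccc3c2=O)C1` gives 100 nM. Compound 1 and compound 3 sit within the scatter of each other, while compound 2 lies beyond the scatter from compound 1. Among the compounds with values here, the one step among the measured compounds, a 1.6-fold lower number from compound 2 to compound 3 (0.20 log units; within the scatter), concerns the amine-bearing side chain and leaves the benzyl arm untouched.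

Compound 4 `CCCCCc1nn(C[C@H]2CCCN2C)c(=O)c2ccccc12` differs from compound 1 at that untouched arm: butyl in place of 3-fluorophenyl on a saturated chain carbon bound to an aromatic carbon. Within the data shown here, no measured step in this assay bears on this position, so the size of the change cannot be read from the data, and the expectation is widened accordingly. Compound 4 is estimated at 150 nM, with a range from 40 nM to 600 nM, which would mean an expected step of a 3.0-fold higher number from compound 1 to compound 4 (0.48 log units; beyond the scatter).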

Compound 4, inhibition constant: 501 nM
Estimate against measurement, compound 4: 3.3-fold (0.52 log units) below; the measured number falls inside the stated range.
By their numbers in this assay, from the lowest: compounds 1, 3 and 2 (each within the scatter of the next, the first and the last beyond it); then compound 4.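

In this assay, the arm of the core proves sensitive to change: going from 3-fluorobenzyl to pentyl, with the aromatic ring and the fluorine both gone, gives a 10-fold higher number from compound 1 to compound 4 (1.00 log units; beyond the scatter). Within the data shown here, this is the first single change at this arm, and unlike a 1.6-fold lower number from compound 2 to compound 3 (0.20 log units; within the scatter) in the amine-bearing side chain, it lies beyond the scatter, so an open carbon chain does not stand in for the 3-fluorophenyl group here. No measurement shown here explains why the number rises.

The compounds shown leave open whether the step follows the loss of the aromatic ring, the loss of the fluorine or the length of the chain. An unsubstituted benzyl, a cyclohexylmethyl group or a longer alkyl chain such as octyl at this position would separate these possibilities.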